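Ether variation on the shared core: isopropyl to isobutyl

A few compounds are considered here, and "the series" means these few. Any claim that something is new, unique, unknown or untested is made for them only; others in the source may bear on it.

Measured compounds in an assay on HEK293 cells for agonist activity at transient receptor potential cation channel subfamily M member 8 (Homo sapiens), read by fluorescence and calcium flux, with a stated time of 5 min; on this read-out lower numbers stand for an effect already at smaller amounts and higher numbers for an effect only at larger amounts of compound:
- compound 1 `C=CCc1cc(OC)c(OC(C)C(O[C@@H]2C[C@H](C)CC[C@H]2C(C)C)c2ccc(O)c(OC)c2)c(OC)c1`: 28 nM
- compound 2 `C=CCc1cc(OC)c(OC(C)C(OCCCCCCCCCC)c2ccc(O)c(OC)c2)c(OC)c1`: 66 nM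
- compound 3 `C=CCc1cc(OC)c(OC(C)C(OC(C)C)c2ccc(O)c(OC)c2)c(OC)c1`: 82 nM

Compound 3 stands at the highest number of the three. Its gap to compound 2 is small, a 1.2-fold higher number from compound 2 to compound 3 (0.09 log units; within the scatter), whereas the gap to compound 1 is larger, a 2.9-fold higher number from compound 1 to compound 3 (0.47 log units; beyond the scatter); compound 1 also sits apart from compound 2, a 2.4-fold higher number from compound 1 to compound 2 (0.37 log units; beyond the scatter).

Compound 4 `C=CCc1cc(OC)c(OC(C)C(OCC(C)C)c2ccc(O)c(OC)c2)c(OC)c1` differs from compound 3 in one place: isobutyl in place of isopropyl on an oxygen on a saturated carbon. Within the data shown here, the only step that bears on it is the chain exchange on the same oxygen from compound 2 to compound 3, which stayed within the scatter. A one-carbon extension of an open chain is therefore expected to move this assay by no more than the scatter, with no direction favoured. Compound 4 is estimated at 70 nM, range 35 nM to 160 nM, which means an expected step of a 1.2-fold lower number from compound 3 to compound 4 (0.07 log units; within the scatter).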

Compound 4, half-maximal effective concentration: 138 nM
For compound 4 the middle estimate is 2.0-fold (0.29 log units) below the measured one; measured number inside the range.
By their numbers in this assay, from the lowest: compound 1; then compounds 2, 3 and 4 (each within the scatter of the next, the first and the last beyond it).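

In this assay, isobutyl in place of isopropyl on the oxygen on a saturated carbon stays within the scatter (a 1.7-fold higher number from compound 3 to compound 4 (0.23 log units; within the scatter)), so this one-carbon change among open chains gives no readable shift. The isobutyl ether nevertheless sits beyond the scatter from the decyl ether (a 2.1-fold higher number from compound 2 to compound 4 (0.32 log units; beyond the scatter)), a separation the isopropyl ether did not show, and also from the 2-isopropyl-5-methylcyclohexyl ether (a 4.9-fold higher number from compound 1 to compound 4 (0.69 log units; beyond the scatter)). Nothing at hand speaks to a cause for these steps.

From the compounds shown here alone, whether the lower number of compound 1 belongs to having a ring on this oxygen or to the ring's own substituents remains open. An unsubstituted cyclohexyl ether or a chain ending in an amine would test how far this position tolerates change.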